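Swapping Methyl for Chloro on a Smaller Core

The source may report more compounds than this note shows. Statements on the series, on what has been measured and on what is new or still open speak of the compounds shown alone.

Compound 1 `CC(=O)OC[C@H]1O[C@H](OC[C@@H](Cn2cc(CN(c3nc(-c4ccc(Cl)cc4)no3)C3CCCCC3)nn2)OC(C)=O)C=C[C@@H]1OC(C)=O` and compound 2 `CC(=O)OC[C@H]1O[C@H](OC[C@@H](Cn2cc(CN(c3nc(-c4ccc(C)cc4)no3)C3CCCCC3)nn2)OC(C)=O)C=C[C@@H]1OC(C)=O` share a large core and differ in a single spot: chloro in place of methyl on an aromatic carbon. In an ADME assay on RAW264.7 cells (Mus musculus) for cytotoxicity, read by MTT assay, with a stated time of 48 h (a lower number here means that less compound is tolerated, a higher number that more compound is tolerated), compound 2 gives 45.3 ug/mL, and compound 1 gives 35.5 ug/mL, so the swap produced a 1.3-fold lower number from compound 2 to compound 1 (0.11 log units; within the scatter). Compound 3 `C#CCN(c1nc(-c2ccc(C)cc2)no1)C1CCCCC1` carries the same 4-methylphenyl group on a much smaller core; how the two cores differ is not broken down here. In this assay compound 3 gives 17.6 ug/mL; against compound 1 the gap stays within the scatter, while against compound 2 it goes beyond it.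

Compound 4 `C#CCN(c1nc(-c2ccc(Cl)cc2)no1)C1CCCCC1` has not yet been measured. It stands to compound 3 exactly as compound 1 stands to compound 2: chloro in place of methyl on an aromatic carbon. The surroundings of the exchanged group read the same in both pairs, so this counts as the same change seen a second time, now on the smaller core. A step of similar size, a 1.2-fold lower number from compound 3 to compound 4 (0.07 log units; within the scatter), is expected, because a 1.3-fold lower number from compound 2 to compound 1 (0.11 log units; within the scatter) stayed within the scatter on the larger core and nothing among these compounds points to a different outcome here. Compound 4 is accordingly expected to land near 15 ug/mL, most plausibly between 8 ug/mL and 28 ug/mL.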

Compound 4, half-maximal cytotoxic concentration: 15.1 ug/mL
Compound 4: middle estimate off by 1.0-fold (0.00 log units), on the low side; low and high end bracket the measured number.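

In this assay, putting chloro in place of methyl on the smaller core gives a 1.2-fold lower number from compound 3 to compound 4 (0.07 log units; within the scatter), so the exchange again leaves the number within the usual scatter of repeated measurements. Set beside the earlier step on the larger core, the two results agree, and the change carries over from one core to the other without any visible shift in its size: the same change on two cores in this assay, a 1.3-fold lower number (0.11 log units; within the scatter) from compound 2 to compound 1 and a 1.2-fold lower number (0.07 log units; within the scatter) from compound 3 to compound 4, 1.1-fold (0.04 log units) apart, within the scatter of two such steps This shows only that two pairs behave alike, at one place on the aromatic ring and in a single cell assay; because neither step rises above the scatter, it does not show that chloro and methyl truly differ here, and two cores cannot establish a rule for the whole series, nor do these numbers explain why the steps match.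

The compounds shown hold only methyl and chloro at this spot, so it remains open whether a carboxylic acid, an amine, a methoxy group or a longer alkyl chain there would also leave the number unchanged on both cores. On these data alone, it also remains open whether chloro and methyl would match each other at a different place on the ring.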